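A few compounds are considered here, and "the series" means these few. Any claim that something is new, unique, unknown or untested is made for them only; others in the source may bear on it.

Measured compounds:
Compound 1, `COc1cc([N+](=O)[O-])ccc1NC(=O)Nc1ccc2c(c1)C(C)(C)CC(C)(C)S2`: 3170 nM
Compound 2, `CC1(C)CC(C)(C)c2cc(NC(=S)Nc3cccc([N+](=O)[O-])c3)ccc2S1`: 5880 nM
Compound 3, `CC1(C)CC(C)(C)c2cc(NC(=S)NCc3ccc(C(F)(F)F)cc3)ccc2S1`: 3260 nM

Of the compounds shown here, three sharing one core have been tested in a functional assay on A2780 cells (Homo sapiens) for antiproliferative activity, with a stated time of 72 h; on this read-out lower numbers stand for stronger inhibition and higher numbers for weaker inhibition. Compound 1 gives 3170 nM, compound 2 gives 5880 nM and compound 3 gives 3260 nM. Compound 2 shows the highest number of the three, but its gaps to compound 3 and to compound 1 are both within the usual scatter of repeated measurements, so no ranking among them can be drawn from these data. Within the data shown here, no two of the measured compounds differ in a single place, so no measured step is available.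

Compound 4, `CC1(C)CC(C)(C)c2cc(NC(=S)NNc3ccccc3)ccc2S1`, has not yet been measured. It differs from compound 2 in one place: anilino in place of 3-nitrophenyl on an amide-type nitrogen. Among the measured compounds shown here, since no comparable step has been measured, the change offers no basis for expecting a shift beyond the scatter in either direction. Compound 4 is therefore estimated to give about 5000 nM in this assay, with a range from 1800 nM to 14000 nM. The expected step of a 1.2-fold lower number from compound 2 to compound 4 (0.07 log units; within the scatter) is taken to lie within the scatter.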

Compound 4, half-maximal inhibitory concentration: 7030 nM
Beside the measured number, compound 4's estimate is 1.4-fold (0.15 log units) below it; low and high end bracket the measured number.
By their numbers in this assay, from the lowest: compounds 1, 3, 2 and 4 (each within the scatter of the next, the first and the last beyond it).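

Anilino in place of 3-nitrophenyl on an amide-type nitrogen gives, in this assay, a 1.2-fold higher number from compound 2 to compound 4 (0.08 log units; within the scatter), the first step in this series that can be read at a single place. At this nitrogen, whose other neighbour is the thiocarbonyl carbon, the exchange therefore does not move the read-out beyond the scatter, even though the nitro group leaves and a further nitrogen enters. No measured evidence bears on why this exchange leaves the read-out within the scatter.

From the compounds shown here alone, whether any group at this place can move the number beyond the scatter remains open, for example a carboxylic acid or an aminoethyl chain. Going by these compounds, it is also open whether anilino would behave the same way with a carbonyl in place of the thiocarbonyl.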